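Chloro to Trifluoromethyl: Expecting the Value for Compound 4

A few compounds are considered here, and "the series" means these few. Any claim that something is new, unique, unknown or untested is made for them only; others in the source may bear on it.

Measured so far, in a functional assay on NCI/ADR-RES cells (Homo sapiens) for inhibition, read by sulforhodamine B assay, with a stated time of 48 h; a lower number here means a stronger inhibitor of growth, a higher number a weaker inhibitor of growth:
compound 1 `COc1cc(-c2nn(-c3cccc(NC(=O)Nc4ccc(Cl)c(Cl)c4)c3)cc2-c2ccncc2)ccc1Cl` gives 990 nM
compound 2 `O=C(Nc1cccc(-n2cc(-c3ccncc3)c(-c3ccc(Cl)c(O)c3)n2)c1)Nc1ccc(Cl)c(Cl)c1` gives 2740 nM
compound 3 `COc1cc(-c2nn(-c3cccc(NC(=O)Nc4cccc(C(F)(F)F)c4)c3)cc2-c2ccncc2)ccc1Cl` gives 783 nM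

Compound 2 stands at the highest of the three numbers, that is, it is the weakest growth inhibitor among them: the step is a 2.8-fold higher number from compound 1 to compound 2 (0.44 log units; beyond the scatter), and compound 3 lies further still below it. Going by the values given here, the only difference between compound 1 and compound 2 is hydrogen in place of methyl on an oxygen on an aromatic ring, so the free hydroxyl variant is the weaker one here.

Compound 4 `O=C(Nc1cccc(-n2cc(-c3ccncc3)c(-c3ccc(Cl)c(O)c3)n2)c1)Nc1ccc(Cl)c(C(F)(F)F)c1` is compound 2 with one change: trifluoromethyl in place of chloro on an aromatic carbon. The closest measured guide is the step from compound 1 to compound 3, which also moved a trifluoromethyl into this region of the molecule, though it removed a chloro at the same time and was a 1.3-fold lower number from compound 1 to compound 3 (0.10 log units; within the scatter). That step stayed within the scatter, so no clear shift is expected in this assay for compound 4 either. Compound 4 is therefore estimated at 2300 nM, with a range from 900 nM to 6000 nM, an expected step of a 1.2-fold lower number from compound 2 to compound 4 (0.08 log units; within the scatter).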

Compound 4, concentration for 50% growth inhibition: 844 nM
Estimate against measurement, compound 4: 2.7-fold (0.44 log units) above; measured number outside the range, below it.
By their numbers in this assay, from the lowest: compounds 3, 4 and 1 (each within the scatter of the next); then compound 2.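

In this assay, replacing 3,4-dichlorophenyl with 4-chloro-3-(trifluoromethyl)phenyl brings a 3.2-fold lower number from compound 2 to compound 4 (0.51 log units; beyond the scatter) and so shows that this one aromatic carbon, ortho to a chloro group and meta to a large group, can shift the number on its own. The earlier step on this ring, which reads a 1.3-fold lower number from compound 1 to compound 3 (0.10 log units; within the scatter) and stayed within the scatter, brought in a trifluoromethyl but also took away a chloro, so it could not show what this carbon does alone. The result also shows that a compound with a free hydroxyl is not held at the high number of compound 2, though nothing given here explains why this change moves the number.

As far as these compounds go, it remains open whether the same swap would bring a similar step in compound 1, which carries a methyl on that oxygen instead of the hydrogen. Also open, from the compounds shown here alone, is how a methyl, a bromo or a nitrile would read at this same carbon, and what would follow if the remaining chloro were replaced by a second trifluoromethyl.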